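Moving the Ring Nitrogen in a Pyridyl Cap

The compounds below may be only part of what the source reports. "The series", "measured", "known", "first", "only" and "open" are said of these compounds alone.

Of the compounds shown here, three built on one shared core have been measured in an in vitro functional assay on 1321-N1 cells for agonist activity at Free fatty acid receptor 1 (Homo sapiens), read by fluorescence, spectrophotometry and calcium flux; a lower number here means a smaller maximal response, a higher number a larger maximal response. Compound 1 `O=C(O)CCc1ccc(C#Cc2ncccc2[N+](=O)[O-])cc1` gives 87%. Compound 2 `O=C(O)CCc1ccc(C#Cc2cccs2)cc1` gives 97%. Compound 3 `O=C(O)CCc1ccc(C#Cc2cccnc2)cc1` gives 96%. All three numbers lie within the usual scatter of one another, so none can be called larger or smaller than the others; compound 3 sits inside this narrow band, with compound 2 nearest to it and compound 1 furthest away. Among the measured compounds shown here, the single measured step that exchanges the ring on the triple-bonded carbon, a number 1 percentage points lower from compound 2 to compound 3 (within the scatter), shows that trading one small aromatic ring for another at this place left the maximal response essentially where it was.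

Compound 4 `O=C(O)CCc1ccc(C#Cc2ccccn2)cc1` is the next step from compound 3. pyridin-2-yl in place of pyridin-3-yl on a triple-bonded carbon The two have the same atoms, joined differently. For the measured compounds named here, the only measured step that bears on this change is the one just described, and it stayed within the scatter. A step of a number 3 percentage points lower from compound 3 to compound 4 (within the scatter) is therefore expected, again within the scatter. For compound 4 the expected value in this assay is 93%, with a range from 80% to 102%.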

Compound 4, largest response reached (reported as efficacy), in percent of the reference or control that the assay uses: 98%
Estimate against measurement, compound 4: 5 percentage points below, within the range that was stated.
By their numbers in this assay, from the lowest: compounds 1, 3, 2 and 4 (each within the scatter of the next, the first and the last beyond it).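

Moving the ring nitrogen, with the same atoms joined differently, gives a number 2 percentage points higher from compound 3 to compound 4 (within the scatter) in this assay and so leaves pyridin-2-yl and pyridin-3-yl on this triple-bonded carbon unseparated by the maximal response. Placing pyridin-2-yl where thiophen-2-yl stood gives a number 1 percentage points higher from compound 2 to compound 4 (within the scatter) and adds one more exchange of rings at this place that the read-out does not separate. The one step here beyond the scatter is a number 11 percentage points higher from compound 1 to compound 4 (beyond the scatter) with hydrogen in place of nitro on an aromatic carbon, so among these compounds only the change of a group carried on the ring, not the change of the ring itself, moves the response, and only modestly.

No measurement at hand explains that modest step. As far as these compounds go, whether nitro is special remains open, since an amine, a chlorine or a methyl on that same aromatic carbon could show whether other groups there give a response like that of compound 1 or like that of compound 4, and a phenyl ring on the triple-bonded carbon would test whether this place tolerates a ring with no hetero atom.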